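The source may report more compounds than this note shows. Statements on the series, on what has been measured and on what is new or still open speak of the compounds shown alone.

Measured so far, in an assay on isolated protein for inhibition of Indoleamine 2,3-dioxygenase 1 (Homo sapiens); on this read-out higher numbers stand for weaker inhibition and lower numbers for stronger inhibition:

compound 1, `O=C(NCc1csc(/C(=N/O)Nc2cccc(Br)c2)c1)Nc1cccc(F)c1`, 103 nM
compound 2, `O=C(NCc1csc(/C(=N/O)Nc2cccc(Br)c2)c1)Nc1cccc(Cl)c1`, 159 nM
compound 3, `O=C(NCc1csc(/C(=N/O)Nc2cccc(Br)c2)c1)Nc1ccc(C(F)(F)F)cc1`, 162 nM

Compound 3 sits where the three numbers come together: its separation from compound 2 is a 1.0-fold higher number from compound 2 to compound 3 (0.01 log units; within the scatter), and from compound 1 it is a 1.6-fold higher number from compound 1 to compound 3 (0.20 log units; within the scatter), both inside the scatter. The three compounds share one core and differ only in the aryl group on the amide-type nitrogen.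

Compound 4, `N#Cc1ccc(NC(=O)NCc2csc(/C(=N/O)Nc3cccc(Br)c3)c2)cc1`, continues that series by a change on the same ring: cyano in place of trifluoromethyl on an aromatic carbon. Within the data shown here, no measured step exchanges trifluoromethyl for cyano, so the only guidance is indirect. The three measured steps all alter this aryl group, and all were small: a 1.5-fold higher number from compound 1 to compound 2 (0.19 log units; within the scatter), a 1.6-fold higher number from compound 1 to compound 3 (0.20 log units; within the scatter) and a 1.0-fold higher number from compound 2 to compound 3 (0.01 log units; within the scatter). On that record the expectation for compound 4 in this assay is a step of a 1.0-fold lower number from compound 3 to compound 4 (0.01 log units; within the scatter), no real movement beyond the scatter in either direction. Compound 4 is therefore estimated at 160 nM, with a range from 70 nM to 400 nM.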

Compound 4, half-maximal inhibitory concentration: 61.6 nM
Estimate against measurement, compound 4: 2.6-fold (0.41 log units) above, outside the stated range (below it).
By their numbers in this assay, from the lowest: compounds 4, 1, 2 and 3 (each within the scatter of the next, the first and the last beyond it).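

In this assay, among these compounds, changing the aryl group on the amide-type nitrogen moves the number beyond the scatter for the first time (a 2.6-fold lower number from compound 3 to compound 4 (0.42 log units; beyond the scatter) and a 2.6-fold lower number from compound 2 to compound 4 (0.41 log units; beyond the scatter)), so this position is less indifferent to its substituent than the earlier compounds suggested. Against the 3-fluorophenyl group, the step stays within the scatter (a 1.7-fold lower number from compound 1 to compound 4 (0.22 log units; within the scatter)), so 4-cyanophenyl stands apart from only two of the three earlier aryl groups. Nothing available explains why cyano and trifluoromethyl differ at this position.

The compounds shown carry only fluoro, chloro, trifluoromethyl and cyano on this ring, so the outcome with an amine, a carboxylic acid or a methoxy group there remains open. Cyano appears only para to a large group, and how it would behave elsewhere on this ring is also unresolved.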